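This account rests on a few compounds, and the source may have more. Where it says the series, first, only, none or still open, it means among the compounds named here.

Series notes, compound 1 and the move to compound 3.

Compound 1 `CCCS(=O)(=O)Nc1ccc(F)c(C(=O)c2n[nH]c3ncc(-c4cccc(Cl)c4)cc23)c1F` is the reference point. In an assay for binding affinity to dual specificity mitogen-activated protein kinase kinase 4 (Homo sapiens), read by KINOMEscan, tested at 100 nM (on this read-out higher numbers stand for a weaker effect at the one concentration tested and lower numbers for a stronger effect), compound 1 gives 40%, the highest of the two numbers recorded so far; its nearest neighbour is compound 2 `CCCS(=O)(=O)Nc1ccc(F)c(C(=O)c2n[nH]c3ncc(-c4cccc(F)c4)cc23)c1F`, which in this assay gives 8.2%. Within the data shown here, the one measured step, a number 31.8 percentage points lower from compound 1 to compound 2 (beyond the scatter), came with fluoro in place of chloro on an aromatic carbon and is large.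

Compound 3 `CCCS(=O)(=O)Nc1ccc(F)c(C(=O)c2n[nH]c3ncc(-c4ccc(N(C)C)cc4)cc23)c1F` has not been measured. Relative to compound 1 the change is 4-(dimethylamino)phenyl in place of 3-chlorophenyl on an aromatic carbon. Among the measured compounds shown here, only the step from compound 1 to compound 2 touches the same position, and it shows that a swap of the group there can shift the read-out by a large amount; the group entering in compound 3 is, however, unlike either of the two measured groups, so the size and direction for compound 3 remain open. Taking the measured spread as the guide, compound 3 is expected to sit close to compound 1 in this assay, with a step of a number 10 percentage points lower from compound 1 to compound 3 (within the scatter) and a wide margin of uncertainty. The estimate for compound 3 is 30%, in the range 5% to 75%.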

Compound 3, a percentage reported as activity, at one concentration (the size of the read-out at that concentration, not a potency): 2.5%
For compound 3 the middle estimate is 27.5 percentage points above the measured one; measured number below the stated range.
By their numbers in this assay, from the lowest: compounds 3 and 2 (each within the scatter of the next); then compound 1.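

Compound 3 shows that a low number at this position does not depend on a halogen-bearing phenyl: the step of a number 37.5 percentage points lower from compound 1 to compound 3 (beyond the scatter) in this assay comes with 4-(dimethylamino)phenyl, a group of a different kind, with 9 heavy atoms against 7 and 1 hydrogen-bond acceptor against 0 for the 3-chlorophenyl it replaces. The further step of a number 5.7 percentage points lower from compound 2 to compound 3 (within the scatter) means that 4-(dimethylamino)phenyl and 3-fluorophenyl cannot be told apart on this read-out, so two quite different groups on this aromatic carbon give the same result within the scatter, and among these three compounds only the 3-chlorophenyl of compound 1 stands apart. No measurement at hand accounts for this behaviour at the position.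

The compounds shown leave open whether the dimethylamino group itself or its place on the phenyl ring matters, which 3-(dimethylamino)phenyl or an unsubstituted phenyl would help to separate. They also leave open whether a saturated amine such as morpholine on the phenyl ring, or a carboxylic acid in that place, would keep the number as low as in compound 3.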